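The compounds below may be only part of what the source reports. "The series", "measured", "known", "first", "only" and "open" are said of these compounds alone.

Compound 1, `COc1ccc(CS(=O)(=O)/C=C/c2ccccc2OC)cc1`, is the reference point of this small series. In a functional assay on DU-145 cells (Homo sapiens) for antiproliferative activity, read by trypan blue exclusion (on this read-out higher numbers stand for weaker inhibition and lower numbers for stronger inhibition), compound 1 gives 3500 nM, the lowest of the two numbers that are reported there. Compound 2, `COc1ccc(CS(=O)(=O)/C=C/c2ccc(F)cc2OC)cc1`, carries fluoro in place of hydrogen on an aromatic carbon and in this assay compound 2 gives 10000 nM, a weakening of a 2.9-fold higher number from compound 1 to compound 2 (0.46 log units; beyond the scatter). Compound 3, `COc1ccc(CS(=O)(=O)/C=C/c2ccc(OC)cc2OC)cc1`, carries methoxy in place of hydrogen on an aromatic carbon. In this assay compound 3 reaches only the limit > 20000 nM, and that limit is a boundary of the assay rather than a number (the limit of > 20000 nM in this assay, at which 1 of the 3 values shown sits). Relative to compound 1 this amounts to an at least 5.7-fold higher number from compound 1 to compound 3 (0.75 log units; beyond the scatter), and relative to compound 2 to an at least 2.0-fold higher number from compound 2 to compound 3 (0.30 log units; that floor lies within the scatter).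

Compound 4, `COc1ccc(CS(=O)(=O)/C=C/c2cc(OC)ccc2OC)cc1`, has not been measured in this assay. It differs from compound 1 by methoxy in place of hydrogen on an aromatic carbon. Among the compounds with values here, the one measured step of the same kind, the methoxy addition from compound 1 to compound 3, was at least modest and went toward weaker inhibition, though it sat at a different position of the same ring. A weakening beyond the scatter is therefore expected for compound 4, with a step of a 2.6-fold higher number from compound 1 to compound 4 (0.41 log units; beyond the scatter) estimated. For compound 4 in this assay the estimate is 9000 nM, within a range of 3500 nM to 25000 nM.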

Compound 4, half-maximal inhibitory concentration: > 20000 nM
Compound 4: a limit, no number (the forecaster's own chance of this, stated with the estimate: 25%); middle value at least 2.2-fold (0.34 log units) away from the limit.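

In this assay compound 4 stands at a limit of the assay, > 20000 nM, and not at a number. Methoxy in place of hydrogen at this place, on an aromatic carbon meta to a large group and para to a methoxy group, gives an at least 5.7-fold higher number from compound 1 to compound 4 (0.75 log units; beyond the scatter), so the weakening that compound 3 showed for this change is not confined to a single position of the ring: two different positions now go the same way relative to compound 1. Compound 3 and compound 4 rest at the same limit, so the two positions cannot be ranked against each other, and the full size of neither step can be read: the limit of > 20000 nM in this assay, at which 2 of the 4 values shown sit.

What the compounds shown leave open is whether the loss belongs to methoxy itself or to any group at this place, since neither an amine nor a hydroxyl group stands on this carbon in the series. Also open, from the compounds shown here alone, is whether a group such as ethoxy would go the same way here, or whether a carboxylic acid at this place would change the direction of the step.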